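Exocyclic double-bond geometry in the bromoacrylamide oxindole series

The compounds below may be only part of what the source reports. "The series", "measured", "known", "first", "only" and "open" are said of these compounds alone.

Measured compounds:
compound 1 `C=C(Br)C(=O)Nc1ccc2c(c1)/C(=C\c1ccsc1)C(=O)N2`: 2600 nM
compound 2 `C=C(Br)C(=O)Nc1ccc2c(c1)CC(=O)N2`: 4500 nM
compound 3 `C=C(Br)C(=O)Nc1ccc2c(c1)/C(=C\c1sccc1C)C(=O)N2`: 450 nM

All three were run in a functional assay on HeLa cells (Homo sapiens) for antiproliferative activity, read by MTT assay, with a stated time of 72 h; on this read-out lower numbers stand for stronger inhibition and higher numbers for weaker inhibition. Compound 2, which lacks the exocyclic arylidene arm, gives 4500 nM. Compound 1 carries a thiophen-3-yl on the exocyclic double bond and gives 2600 nM. Among the compounds with values here, compound 3, bearing 3-methylthiophen-2-yl in the same place, gives 450 nM and stands lowest of the three numbers; the only single-point step here is a 5.8-fold lower number from compound 1 to compound 3 (0.76 log units; beyond the scatter), and the gap to compound 2 is beyond the scatter as well.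

Compound 4 `C=C(Br)C(=O)Nc1ccc2c(c1)/C(=C/c1sccc1C)C(=O)N2` is the geometric isomer of compound 3: the two compounds have the same atoms and bonds and differ only in configuration as drawn: 1 of 1 stereo elements differ; a double bond is drawn E in compound 3 and Z in compound 4. Within the data shown here, no measured pair in this set differs in double-bond geometry, so the step from compound 1 to compound 3 does not bear directly on it and the direction is uncertain. A change within or near the scatter in this assay is taken as the central case, with wide room for either isomer to be the more potent. Compound 4 is therefore expected at 800 nM, range 150 nM to 4000 nM, a step of a 1.8-fold higher number from compound 3 to compound 4 (0.25 log units; within the scatter).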

Compound 4, half-maximal inhibitory concentration: 420 nM
Beside the measured number, compound 4's estimate is 1.9-fold (0.28 log units) above it, within the range that was stated.
By their numbers in this assay, from the lowest: compounds 4 and 3 (each within the scatter of the next); then compounds 1 and 2 (each within the scatter of the next).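

In this assay, double-bond geometry on the 3-methylthiophen-2-yl arm leaves the number unchanged within the scatter, with a 1.1-fold lower number from compound 3 to compound 4 (0.03 log units; within the scatter). Within the data shown here, this is the first reading of geometry alone, and the comparison isolates that single variable: the fact that compounds 3 and 4 differ only in the configuration as drawn. Of the two single-place steps read so far, only the change of arm moves the number beyond the scatter, with a 5.8-fold lower number from compound 1 to compound 3 (0.76 log units; beyond the scatter), so at this position the identity of the arm registers in this assay and its drawn geometry does not.

Open, on these data alone, is whether this holds for other arms, such as the thiophen-3-yl of compound 1 or a ring carrying an amine or a carboxylic acid in place of the methyl. Also open, as far as these compounds go, is whether compound 3 and compound 4 each keep their drawn geometry throughout this assay.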